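The source may report more compounds than this note shows. Statements on the series, on what has been measured and on what is new or still open speak of the compounds shown alone.

Compound 1 `Cn1nccc1-c1cc(C(F)(F)F)ccc1[C@H]1CCc2cc(S(=O)(=O)Nc3ncccn3)ccc21`: 2.4
Compound 2 `Cn1nccc1-c1cc(C(F)(F)F)ccc1[C@@H]1CCOc2cc(S(=O)(=O)Nc3nccs3)ccc21`: 2.2
Compound 3 `Cn1nccc1-c1cc(C(F)(F)F)ccc1[C@H]1CCOc2cc(S(=O)(=O)Nc3nccs3)ccc21`: 2.2

Of the compounds shown here, three have been measured in a physicochemical assay for lipophilicity; on this read-out higher numbers stand for higher lipophilicity and lower numbers for lower lipophilicity. Compound 1 gives the highest of the three numbers, but its nearest and furthest neighbours, compound 2 and compound 3, lie within the usual scatter of it, so the three cannot be ordered on these data. Within the data shown here, the only step between two compounds that differ in one place is no change at the digits printed from compound 2 to compound 3 (within the scatter); it is explained by the fact that compounds 2 and 3 differ only in the configuration as drawn and therefore says nothing about swapping one ring for another.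

Compound 4 `O=S(=O)(Nc1ncccn1)c1ccc2c(c1)CC[C@@H]2c1ccc(C(F)(F)F)cc1-c1ccc(F)nc1` has not yet been measured. It differs from compound 1 in one place: 6-fluoropyridin-3-yl in place of 1-methyl-1H-pyrazol-5-yl on an aromatic carbon

Among the measured compounds shown here, no measured step bears on this exchange of an aromatic ring, so the expectation rests on the structural change alone and on the narrow band occupied by the three measured compounds. The step from compound 1 to compound 4 is expected to be a number 0.70 log units higher from compound 1 to compound 4 (beyond the scatter) in this assay, an increase beyond the scatter. Compound 4 is therefore estimated at 3.1, with a range from 2.5 to 3.7.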

Compound 4, distribution coefficient: 3.2
Compound 4: the middle estimate sits 0.10 log units below what was measured, within the range that was stated.
By their numbers in this assay, from the lowest: compounds 2, 3 and 1 (each within the scatter of the next); then compound 4.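

In this assay, putting 6-fluoropyridin-3-yl in place of 1-methyl-1H-pyrazol-5-yl gives a number 0.80 log units higher from compound 1 to compound 4 (beyond the scatter), the first step among these compounds to lie beyond the scatter. The earlier comparison concerned only a change of drawn configuration, whereas this one shows that exchanging the aromatic ring on this aromatic carbon, ortho to a large group and meta to a trifluoromethyl group, can clearly shift the read-out. Nothing given here accounts for the size of this step.

A single exchange alters the ring size, the ring hetero atoms and the presence of fluorine together, so the compounds shown leave open which of these changes carries the step, and whether the same exchange would give a similar step on the core of compound 2 or compound 3. They also leave open where the read-out would fall with a plain pyridin-3-yl group without the fluorine, or with a ring bearing an amine or a carboxylic acid, at this position.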